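A few compounds are considered here, and "the series" means these few. Any claim that something is new, unique, unknown or untested is made for them only; others in the source may bear on it.

Measured so far in a functional assay with Rattus norvegicus as the target; a higher number here means a weaker inhibitor, a lower number a stronger inhibitor:

compound 1, `O=C(/C=C/c1ccncc1)c1cccc(C(F)(F)F)c1`, 41000 nM
compound 2, `CN(C)c1cccc(C(=O)/C=C/c2ccncc2)c1`, 19000 nM
compound 3, `O=C(/C=C/c1ccncc1)c1ccc(C(F)(F)F)cc1`, 204000 nM

Compound 1 and compound 2 share one core and differ in a single group: dimethylamino in place of trifluoromethyl on an aromatic carbon. That exchange gave a 2.2-fold lower number from compound 1 to compound 2 (0.33 log units; beyond the scatter), so compound 2 is the stronger inhibitor of the pair.

Compound 3 has the same atoms as compound 1, joined differently; the difference between the two cores is not broken down here. Its number is the highest of the three, so it is the weakest inhibitor among the measured compounds.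

Compound 4, `CN(C)c1ccc(C(=O)/C=C/c2ccncc2)cc1`, is not yet measured. It stands to compound 3 as compound 2 stands to compound 1: dimethylamino in place of trifluoromethyl on an aromatic carbon. The surroundings are not identical, since in compound 2 the new group sits meta to a large group and in compound 4 it sits para to a large group, so this is the same kind of change rather than the same change. The expectation is that this exchange lowers the number about as the step of a 2.2-fold lower number from compound 1 to compound 2 (0.33 log units; beyond the scatter) did, giving an estimated 2.3-fold lower number from compound 3 to compound 4 (0.36 log units; beyond the scatter). Compound 4 is therefore estimated at 90000 nM, within 30000 nM to 250000 nM.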

Compound 4, half-maximal inhibitory concentration: 11000 nM
Estimate against measurement, compound 4: 8.2-fold (0.91 log units) above; measured number outside the range, below it.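

In this assay, dimethylamino in place of trifluoromethyl lowered the number on both cores, but the size of the step did not carry over, with a 19-fold lower number from compound 3 to compound 4 (1.27 log units; beyond the scatter). Set side by side, the two steps differ by more than repeated measurements would explain: the same change on two cores in this assay, a 2.2-fold lower number (0.33 log units; beyond the scatter) from compound 1 to compound 2 and a 19-fold lower number (1.27 log units; beyond the scatter) from compound 3 to compound 4, 8.6-fold (0.93 log units) apart, beyond the scatter of two such steps. The direction of this change therefore held on the two cores shown, while a step measured on one core proved a poor guide to its size on the other; two pairs cannot show why the steps differ, or what the same change would do on any further core in the series.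

The compounds shown leave open whether another group on the same aromatic carbon, such as methoxy or a carboxylic acid, would give a number nearer to that of dimethylamino or of trifluoromethyl on these cores. Also open, going by these compounds, is where a plain hydrogen at that carbon would fall, which would show how far each of the two groups moves the number on its own.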